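Swapping One Aryl Group on a Weak Compound

This account rests on a few compounds, and the source may have more. Where it says the series, first, only, none or still open, it means among the compounds named here.

Measured in a functional assay on HCT-116 cells (Homo sapiens) for antiproliferative activity, read by MTT assay, with a stated time of 72 h; on this read-out higher numbers stand for weaker inhibition and lower numbers for stronger inhibition:
Compound 1 `CC(C)(C)c1ccc(OCCCON2C(N)=NC(N)=NC23CCSCC3)cc1`: 1 nM
Compound 2 `COc1ccc(OCCCON2C(N)=NC(N)=NC23CCOCC3)cc1`: 1500 nM

Compound 2 has the higher number of the two, so it is the weaker inhibitor, and the gap to compound 1 lies well beyond the scatter. Compound 3 `NC1=NC2(CCOCC2)N(OCCCOc2ccccc2Cl)C(N)=N1` differs from compound 2 in one place: 2-chlorophenyl in place of 4-methoxyphenyl on an oxygen on a saturated carbon. Within the data shown here, no measured pair shows what this swap does, so the expectation stays near compound 2 at 1500 nM, with only a modest shift toward stronger inhibition expected. The estimated move is a 1.9-fold lower number from compound 2 to compound 3 (0.27 log units; within the scatter). For compound 3 the estimated value is 800 nM, with an expected range from 120 nM to 5000 nM.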

Compound 3, half-maximal inhibitory concentration: 70 nM
The estimate for compound 3 lay 11-fold (1.06 log units) above the measured number; the measured number lies below the stated range.
By their numbers in this assay, from the lowest: compound 1; then compound 3; then compound 2.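

Putting 2-chlorophenyl in place of 4-methoxyphenyl on an oxygen on a saturated carbon gives a 21-fold lower number from compound 2 to compound 3 (1.33 log units; beyond the scatter) with the rest of the molecule unchanged. This shows that the aryl group alone can strongly change antiproliferative activity, which the earlier pair could not show since its compounds differ in more than one place. No measurement shown here explains the gain.

From the compounds shown here alone, it remains open whether the chlorine or its place on the ring matters more. Plain phenyl and 4-chlorophenyl would help separate the two.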